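A few compounds are considered here, and "the series" means these few. Any claim that something is new, unique, unknown or untested is made for them only; others in the source may bear on it.

Three compounds built on a shared core were tested in an ADME assay on MT4 cells (Homo sapiens) for cytotoxicity, read by MTT assay, with a stated time of 5 days; a lower number here means that less compound is tolerated, a higher number that more compound is tolerated. Compound 1 `Cc1cc(C#N)cc(C)c1Oc1ccnc(Nc2ccc(CN3CCC(NC(=O)OC(C)(C)C)CC3)cc2)n1` gives 4340 nM, the second highest of the three numbers. Compound 2 `Cc1cc(C#N)cc(C)c1Oc1ccnc(Nc2ccc(CN3CCC(NS(C)(=O)=O)CC3)cc2)n1` gives 18100 nM, and compound 3 `Cc1cc(C#N)cc(C)c1Oc1ccnc(Nc2ccc(CN3CCC(NS(N)(=O)=O)CC3)cc2)n1` gives 3720 nM. These three differ only in the group carried on an amine nitrogen: there is a 4.2-fold higher number from compound 1 to compound 2 (0.62 log units; beyond the scatter), there is a 1.2-fold lower number from compound 1 to compound 3 (0.07 log units; within the scatter), and there is a 4.9-fold lower number from compound 2 to compound 3 (0.69 log units; beyond the scatter).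

Compound 4 `Cc1cc(/C=C/C#N)cc(C)c1Oc1ccnc(Nc2ccc(CN3CCC(NC(=O)OC(C)(C)C)CC3)cc2)n1` keeps the group of compound 1 on that amine nitrogen and changes a different part of the molecule: 2-cyanoethenyl in place of cyano on an aromatic carbon. None of the three measured steps touches this aromatic position, so none of them bears directly on the change, and there is no measured guide to its size or direction in this assay. The expectation is therefore that compound 4 shows no step beyond the usual scatter relative to compound 1, that is, a step of a 1.0-fold lower number from compound 1 to compound 4 (0.00 log units; within the scatter). Compound 4 is estimated at 4300 nM, with a range from 1400 nM to 13000 nM.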

Compound 4, half-maximal cytotoxic concentration: 3550 nM
Estimate against measurement, compound 4: 1.2-fold (0.08 log units) above; the measured number falls inside the stated range.
By their numbers in this assay, from the lowest: compounds 4, 3 and 1 (each within the scatter of the next); then compound 2.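

In this assay, replacing cyano with the longer 2-cyanoethenyl group on this aromatic carbon gives a 1.2-fold lower number from compound 1 to compound 4 (0.09 log units; within the scatter), so this particular change leaves no mark beyond the scatter. Within the data shown here, the earlier compounds differed only in the group on the amine nitrogen, where steps beyond the scatter do appear, whereas this is the first reading from the other end of the molecule, and it holds for this one pair only. Nothing shown here gives a reason for this result.

On these data alone, it remains open whether 2-cyanoethenyl would behave the same way alongside the methylsulfonyl group of compound 2 or the sulfamoyl group of compound 3. As far as these compounds go, it is also open how a different group on this aromatic carbon, such as an amine or a carboxylic acid, would fare.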